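The source may report more compounds than this note shows. Statements on the series, on what has been measured and on what is new or still open speak of the compounds shown alone.

Values in a functional assay on A549 cells (Homo sapiens) for antiproliferative activity, read by sulforhodamine B assay, with a stated time of 48 h; a lower number here means a stronger inhibitor, a higher number a weaker inhibitor:
- compound 1 `COc1ccc(C(=O)/C=C/c2ccccc2-c2ccc(F)cc2)cc1` gives 8200 nM
- compound 2 `COc1ccc(C(=O)/C=C/c2ccccc2-c2ccc(F)nc2)cc1` gives > 50000 nM (a limit)
- compound 3 `COc1ccc(C(=O)/C=C/c2ccccc2-c2ccc(F)nc2)cc1OC` gives 17000 nM

Compound 2 stands at the limit of > 50000 nM in this assay, at which 1 of the 3 values shown sits. That entry is a limit of the assay and not a number, so any step starting from compound 2 is known only from one side.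

Compound 4 `O=C(/C=C/c1ccccc1-c1ccc(F)nc1)c1cccc(O)c1` differs from compound 2 at one place: 3-hydroxyphenyl in place of 4-methoxyphenyl on a carbonyl carbon. This puts 3-hydroxyphenyl in place of 4-methoxyphenyl on a carbonyl carbon.

The closer measured change is an at least 2.9-fold lower number from compound 2 to compound 3 (0.46 log units; beyond the scatter), since it alters the same group on the carbonyl carbon. The other change is an at least 6.0-fold higher number from compound 1 to compound 2 (0.78 log units; beyond the scatter), which leaves that group untouched and bears only on the level from which compound 4 starts. For the measured compounds named here, no measured compound carries 3-hydroxyphenyl, so the size of the new step is poorly fixed. On the strength of an at least 2.9-fold lower number from compound 2 to compound 3 (0.46 log units; beyond the scatter), a modest move to a lower number is expected in this assay, although a second limit reading remains possible.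

The estimated step is an at least 2.0-fold lower number from compound 2 to compound 4 (0.30 log units; that floor lies within the scatter).

For compound 4 the estimated value is 25000 nM, with an expected range of 8000 nM to 60000 nM.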

Compound 4, half-maximal inhibitory concentration: 6900 nM
Beside the measured number, compound 4's estimate is 3.6-fold (0.56 log units) above it, outside the stated range (below it).
By their numbers in this assay, from the lowest: compounds 4 and 1 (each within the scatter of the next); then compound 3. At a limit, above all of these: compound 2.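

In this assay, exchanging the whole aryl group on the carbonyl carbon, 3-hydroxyphenyl in place of 4-methoxyphenyl, gives an at least 7.2-fold lower number from compound 2 to compound 4 (0.86 log units; beyond the scatter). For the compounds shown here, until now the only change at this position was the added methoxy of compound 3, which kept the 4-methoxyphenyl pattern and left an oxygen substituent without a hydrogen-bond donor; compound 4 shows that this position also tolerates a group with a hydrogen-bond donor and one heavy atom fewer, and that a measurable value can be recovered in the 6-fluoropyridin-3-yl series without any methoxy group. The step is known from one side only, and its true size cannot be read, nor can it be ranked against the step to compound 3, since both start from a limit of the assay held by compound 2: the limit of > 50000 nM in this assay, at which 1 of the 4 values shown sits.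

The shown compounds do not separate the effect of the hydroxy group from that of moving the substituent, which 3-methoxyphenyl or 4-hydroxyphenyl on the carbonyl carbon would address. From the compounds shown here alone, it also remains open whether 3-hydroxyphenyl behaves alike with the 4-fluorophenyl of compound 1, and how an amine or a carboxylic acid in place of the hydroxy group would read.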